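The compounds below may be only part of what the source reports. "The series", "measured", "known", "first", "only" and "open" are said of these compounds alone.

Measured compounds:
- compound 1 `COc1ccccc1NC(=O)Nc1cccc(CNc2ncnc3cc(OC)c(OC)cc23)c1`: 27200 nM
- compound 2 `COc1cc2ncnc(NCc3cccc(NC(=O)Nc4ccc(F)cc4)c3)c2cc1OC`: 36600 nM

Compound 2 holds the highest of the two numbers in a functional assay on HepG2 cells (Homo sapiens) for antiproliferative activity, read by MTT assay (on this read-out lower numbers stand for stronger inhibition and higher numbers for weaker inhibition), and its nearest neighbour is compound 1, whose result lies within the scatter of it: the change from 2-methoxyphenyl to 4-fluorophenyl on an amide-type nitrogen gave a 1.3-fold higher number from compound 1 to compound 2 (0.13 log units; within the scatter), so the two compounds cannot be ranked against each other on this read-out.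

Compound 3 `COc1cc2ncnc(NCc3cccc(NC(=O)Nc4ccc(Cl)cc4)c3)c2cc1OC` is the next member of the series. It differs from compound 2 by chloro in place of fluoro on an aromatic carbon, that is, a chloro in place of a fluoro on an aromatic carbon of a six-membered aromatic ring of carbon only, para to a large group. Among the measured compounds shown here, the only measured step, the one from compound 1 to compound 2, touched the same phenyl ring and stayed within the scatter; no measured step compares chloro with fluoro. On this footing compound 3 is expected to show a step of a 1.1-fold lower number from compound 2 to compound 3 (0.04 log units; within the scatter) in this assay, nothing beyond the scatter in either direction. Compound 3 is therefore estimated at 33000 nM, with a range from 14000 nM to 80000 nM.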

Compound 3, half-maximal inhibitory concentration: > 50000 nM
Compound 3 was reported as a limit; the forecaster's own chance of this, stated with the estimate: 10%; at least 1.5-fold (0.18 log units) between middle value and limit.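

Compound 3 is reported only as a limit in this assay, not as a number: the limit of > 50000 nM in this assay, at which 1 of the 3 values shown sits. Chloro in place of fluoro on an aromatic carbon, para to a large group, gives an at least 1.3-fold higher number from compound 2 to compound 3 (0.13 log units; that floor lies within the scatter), and 4-chlorophenyl in place of 2-methoxyphenyl on the amide-type nitrogen gives an at least 1.8-fold higher number from compound 1 to compound 3 (0.26 log units; that floor lies within the scatter); both are floors that lie within the scatter, so the real size of either step stays unfixed. Among the compounds shown here, this is the first direct comparison of the two halogens at this position, and what it adds is that chloro brings no sign of stronger inhibition than fluoro, while compound 3 may sit level with compound 2 or well beyond it.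

The compounds shown leave open how this position responds to a group other than fluoro or chloro, such as bromo, a nitrile or an amine. They also leave open whether any change on this phenyl ring can move the number beyond the scatter in the direction of stronger inhibition, for instance a hydroxyl or a carboxylic acid in the same place.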